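This account rests on a few compounds, and the source may have more. Where it says the series, first, only, none or still open, it means among the compounds named here.

Measured in a functional assay for inhibition, with Rattus norvegicus as the target; a higher number here means a weaker inhibitor, a lower number a stronger inhibitor:
- compound 1 `CCC/N=c1\c(O)c(O)\c1=N/c1cccnc1`: > 30000 nM (a limit)
- compound 2 `CC(/N=c1\c(O)c(O)\c1=N/c1ccc(OC(F)(F)F)cc1)C(C)(C)C`: > 30000 nM (a limit)
- compound 3 `CC(C)(C)/N=c1\c(O)c(O)\c1=N/c1ccc(C#N)cc1`: 560 nM

Among the measured compounds shown here, compound 3 holds the only actual number in this small set. The other two results are limits, and the picture in this assay is therefore thin: the limit of > 30000 nM in this assay, at which 2 of the 3 values shown sit. For the measured compounds named here, no pair of measured compounds differs in a single place, so the series offers no direct measure of any one structural change.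

The next compound, compound 4 `CCC(C)(C)/N=c1\c(O)c(O)\c1=N/c1ccc(C#N)cc1`, differs from compound 3 in one place: methyl in place of hydrogen on a saturated chain carbon, two bonds along the chain from a double-bonded nitrogen. Read one bond further out, tert-butyl becomes 1,1-dimethylpropyl, and the rest of the structure stays the same.

The expectation starts from compound 3 at 560 nM, as no measured neighbour gives a closer anchor. A single added methyl on a chain that is already branched is not expected to shift the result much. In this assay, the expected change is a 1.2-fold lower number from compound 3 to compound 4 (0.09 log units; within the scatter), with none beyond the scatter in either direction, although a small gain in strength would not be surprising. For compound 4 the estimated value is 450 nM, with an expected range of 130 nM to 1500 nM.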

Compound 4, half-maximal inhibitory concentration: > 30000 nM
Compound 4 was reported as a limit; the forecaster's own chance of this, stated with the estimate: 5%; at least 66-fold (1.82 log units) between middle value and limit.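

In this assay, this single change gives the first direct measure in the series: the addition of one methyl, which turns tert-butyl into 1,1-dimethylpropyl, gives an at least 53-fold higher number from compound 3 to compound 4 (1.72 log units; beyond the scatter). The saturated chain carbon, two bonds along the chain from a double-bonded nitrogen, therefore does not take this extra methyl without a loss of inhibition beyond the scatter, even though the chain is already branched and the rest of the structure stays the same. Compound 4 is reported as a limit, so the step has a bound and no exact size, and the series still rests on very few actual numbers: the limit of > 30000 nM in this assay, at which 3 of the 4 values shown sit.

On these data alone, it remains open whether any other group in place of tert-butyl, such as isopropyl or cyclobutyl, would keep the inhibition seen with compound 3, or whether the tert-butyl group is the only one tolerated here. Compound 1 and compound 2 each differ from compound 3 in more than one place, so the contribution of the nitrile on the aromatic ring also remains unresolved.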